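A Chloro Analogue Tested for Paw Edema Inhibition

A few compounds are considered here, and "the series" means these few. Any claim that something is new, unique, unknown or untested is made for them only; others in the source may bear on it.

The series shares one core, seen in compound 1 `O=C(NCc1ccccc1)c1c(O)c2cccnc2n(-c2ccccc2)c1=O`, where a benzyl group sits on the amide-type nitrogen. In a functional assay on the whole organism for inhibition, with Rattus norvegicus as the target, read by paw edema, at a dose of 100 mg/kg by the oral route (a higher number here means more inhibition at the dose given (going by the name of the read-out), a lower number less inhibition), compound 1 gives 1.6%. Compound 2 `COc1ccc(NC(=O)c2c(O)c3cccnc3n(-c3ccccc3)c2=O)cc1` carries a 4-methoxyphenyl group in place of benzyl on that nitrogen, and in this assay compound 2 gives 0.3%. Among the measured compounds shown here, the only step between measured compounds, a number 1.3 percentage points lower from compound 1 to compound 2 (within the scatter), is within the scatter, so the two results cannot be told apart. Compound 2 thus stands at the lower of the two numbers, with compound 1 within the scatter of it.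

Compound 3 `O=C(Nc1ccc(Cl)cc1)c1c(O)c2cccnc2n(-c2ccccc2)c1=O` differs from compound 2 in one place: chloro in place of methoxy on an aromatic carbon. For the measured compounds named here, no measured step touches this exact change, but the one step that exists shows that a replacement on the amide-type nitrogen left the read-out where it was. Compound 3 is therefore expected to give 2% in this assay, between -8% and 12%. The step this estimate means, a number 1.7 percentage points higher from compound 2 to compound 3 (within the scatter), is expected to stay within the scatter.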

Compound 3, a percentage reported as inhibition, in the whole organism at one dose (the size of the read-out at that dose, not a potency): 11.6%
Estimate against measurement, compound 3: 9.6 percentage points below; the measured number falls inside the stated range.
By their numbers in this assay, from the lowest: compounds 2, 1 and 3 (each within the scatter of the next, the first and the last beyond it).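

The change on the aromatic carbon, para to a large group, is what separates compounds here: in this assay, chloro in place of methoxy gives a number 11.3 percentage points higher from compound 2 to compound 3 (beyond the scatter), a modest step. The earlier compounds had shown only a swap on the amide-type nitrogen that stayed within the scatter, so this is the first sign that the read-out can respond to the group on this phenyl ring. The other new step, 4-chlorophenyl in place of benzyl on the amide-type nitrogen, gives a number 10 percentage points higher from compound 1 to compound 3 (within the scatter), so compound 3 cannot be told apart from compound 1, and nothing available explains the difference between the methoxy and chloro compounds.

From the compounds shown here alone, with a single pair behind it, the step from methoxy to chloro remains one observation, and it is open whether it would carry over to other amide groups such as the benzyl group of compound 1. Going by these compounds, it is also open how a fluoro, a nitrile, a carboxylic acid or an amine at the same place on the ring would read in this assay, and whether any such group would move the number further than chloro does.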